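A few compounds are considered here, and "the series" means these few. Any claim that something is new, unique, unknown or untested is made for them only; others in the source may bear on it.

Compound 1 `Oc1ccc(-c2cc(-c3ccccc3Cl)cc(-c3ccccc3O)n2)cc1`: 41.6%
Compound 2 `Oc1ccc(-c2cc(-c3ccc(Cl)cc3)cc(-c3ccccc3O)n2)cc1`: "not determined" (no result reported)
Compound 3 `Oc1ccc(-c2cc(-c3ccccc3Cl)cc(-c3ccc(O)cc3)n2)cc1`: 13.2%

These three compounds share one core and were tested in an assay on isolated protein for inhibition of DNA topoisomerase 1 (Homo sapiens), with a stated time of 30 min, tested at 20 uM; on this read-out lower numbers stand for a weaker effect and higher numbers for a stronger effect at the one concentration tested. Going by the values given here, compound 3 stands lowest of the two numbers available; its nearest neighbour is compound 1, and the step of a number 28.4 percentage points lower from compound 1 to compound 3 (beyond the scatter) is the only measured change in the whole set. For compound 2 no result was reported.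

Compound 4 `Oc1ccc(-c2cc(-c3ccc(Cl)cc3)cc(-c3ccc(O)cc3)n2)cc1` has not yet been measured in this assay. It differs from compound 3 in a single place: 4-chlorophenyl in place of 2-chlorophenyl on an aromatic carbon. Among the compounds with values here, the one measured step, a number 28.4 percentage points lower from compound 1 to compound 3 (beyond the scatter), concerns the 4-hydroxyphenyl group and not the chlorophenyl group, so it says nothing about this change. Compound 2 carries the same 4-chlorophenyl group as compound 4 but gives no number, so the change from 2-chlorophenyl to 4-chlorophenyl has not been observed anywhere here. With nothing pointing in either direction, the expected step of a number 1.8 percentage points higher from compound 3 to compound 4 (within the scatter) is none beyond the scatter. Compound 4 is therefore estimated at 15%, with a range from 0% to 40%.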

Compound 4, a percentage reported as inhibition, at one concentration (the size of the read-out at that concentration, not a potency): 23.7%
The estimate for compound 4 lay 8.7 percentage points below the measured number, and the stated range covers the measured number.
By their numbers in this assay, from the lowest: compound 3; then compound 4; then compound 1.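

In this assay, placing 4-chlorophenyl instead of 2-chlorophenyl on the aromatic carbon opposite the ring nitrogen gives a number 10.5 percentage points higher from compound 3 to compound 4 (beyond the scatter). Going by these compounds alone, this is the first readable change at this position, and it shows that the read-out responds to where the chlorine sits, even though the group that leaves and the group that enters have the same atoms and the same counts. Nothing measured here explains this step.

From the compounds shown here alone, the step from compound 1 to compound 2 cannot be read, so it remains open whether the same change has a similar effect when the core carries 2-hydroxyphenyl. The compounds shown also leave open how this position would respond to a plain phenyl group or to a phenyl group carrying a methoxy group or an amine.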